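Swapping 4-Methoxybenzyl for 3-Methoxybenzyl

The source may report more compounds than this note shows. Statements on the series, on what has been measured and on what is new or still open speak of the compounds shown alone.

Among the compounds with values here, two related compounds have numbers so far, compound 1 `COc1ccc2cc([C@H](C)c3nnc(SCc4c(C)cc(C)cc4C)n3-c3cccc(Cl)c3)ccc2c1` and compound 2 `COc1ccc(CSc2nnc([C@@H](C)c3ccc4cc(OC)ccc4c3)n2-c2ccc(Cl)cc2)cc1`. In a functional assay on DU-145 cells (Homo sapiens) for cytotoxicity, read by MTT assay (on this read-out lower numbers stand for stronger inhibition and higher numbers for weaker inhibition), compound 2 gives 72600 nM and compound 1 gives 93300 nM. These two values lie within the usual scatter of repeated measurements, so the data cannot rank one above the other.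

The next molecule, compound 3 `COc1cccc(CSc2nnc([C@@H](C)c3ccc4cc(OC)ccc4c3)n2-c2ccc(Cl)cc2)c1`, has not yet been measured. It contains the same atoms as compound 2, joined differently: 3-methoxyphenyl in place of 4-methoxyphenyl on a saturated chain carbon bound to a sulfur. In plain terms, 3-methoxyphenyl stands in place of 4-methoxyphenyl on a saturated chain carbon bound to a sulfur, and the rest of the molecule stays the same.

Within the data shown here, no measured pair shows a change of this kind, so the only guide is compound 2 at 72600 nM, together with its close neighbour. On that basis, no change beyond the scatter is expected in this assay, and the estimated 1.0-fold lower number from compound 2 to compound 3 (0.02 log units; within the scatter) is small. For compound 3, the estimated value is 70000 nM, with an expected range from 35000 nM to 140000 nM.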

Compound 3, half-maximal inhibitory concentration: <= 400000 nM
Compound 3: no number, only a limit; the forecaster's own chance of this, stated with the estimate: 20%; the middle value does not contradict the limit.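

In this assay compound 3 gives <= 400000 nM and this is a limit, not a number. Within the data shown here, no step from compound 2 to compound 3 can therefore be read, because the only result for compound 3 is this limit: the limit of <= 400000 nM in this assay, at which 1 of the 3 values shown sits. The compounds shown leave open whether 3-methoxyphenyl in place of 4-methoxyphenyl changes the number at all.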